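Working notes on two sulfonamides and one untested analogue

A few compounds are considered here, and "the series" means these few. Any claim that something is new, unique, unknown or untested is made for them only; others in the source may bear on it.

Measured compounds:
compound 1 `O=C1[C@@H](NS(=O)(=O)c2cc3ccnc(Cl)c3s2)CCN1Cc1cc2[nH]cccc-2n1`, 45%
compound 2 `O=C1[C@@H](NS(=O)(=O)c2cc3cccnc3s2)CCN1Cc1cc2c[nH]ccc-2n1`, 18%

In an assay on isolated protein for inhibition of coagulation factor X (Oryctolagus cuniculus), tested at 1 uM (on this read-out higher numbers stand for more inhibition at the one concentration tested (going by the name of the read-out) and lower numbers for less inhibition), compound 1 gives 45% and compound 2 gives 18%. Compound 2 stands lowest of the two numbers, and its gap to compound 1 lies beyond the scatter. Within the data shown here, compounds 1 and 2 differ in two places at once, so no single step can be read between them; their two values show only that the pair spans a wide range in this assay.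

Compound 3 `O=C1[C@@H](NS(=O)(=O)c2cc3ccnc(Cl)c3s2)CCN1Cc1cc2c[nH]ccc-2n1` is not yet measured. It keeps the core of compound 2 and changes only the group on the sulfonyl sulfur: a group of 10 heavy atoms (7 carbon, 1 nitrogen, 1 sulfur, 1 chlorine; one five-membered aromatic ring with 1 hetero atom, one six-membered aromatic ring with 1 hetero atom) in place of a group of 9 heavy atoms (7 carbon, 1 nitrogen, 1 sulfur; one five-membered aromatic ring with 1 hetero atom, one six-membered aromatic ring with 1 hetero atom), on a sulfonyl sulfur. Among the measured compounds shown here, the entering group is the one carried by compound 1. For the measured compounds named here, no measured step isolates this change, since compound 1 also differs from compound 2 in the core. Because compound 1 reaches 45% with the same sulfonyl group, an upward step of moderate size is expected, though the core difference leaves this uncertain. The expected step is a number 17 percentage points higher from compound 2 to compound 3 (beyond the scatter). For compound 3 the estimated value in this assay is 35%, with a range from 15% to 55%.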

Compound 3, a percentage reported as inhibition, at one concentration (the size of the read-out at that concentration, not a potency): 25%
The estimate for compound 3 lay 10 percentage points above the measured number; low and high end bracket the measured number.
By their numbers in this assay, from the lowest: compounds 2 and 3 (each within the scatter of the next); then compound 1.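

In this assay the exchange on the sulfonyl sulfur, on the core of compound 2, stays within the scatter (a number 7 percentage points higher from compound 2 to compound 3 (within the scatter)), so the chlorine-bearing group of 10 heavy atoms and the group of 9 heavy atoms it replaces cannot be told apart on this core. With the sulfonyl group held constant, the change on the saturated chain carbon bound to an amide-type nitrogen in a ring is a modest step beyond the scatter (a number 20 percentage points lower from compound 1 to compound 3 (beyond the scatter)), even though the two groups exchanged there have the same heavy-atom count. Of the two places in which compound 1 and compound 2 differ, only this second one gives a step beyond the scatter among the steps that can be read here.

No measurement at hand bears on the reason for either step.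

Open, from the compounds shown here alone, is whether the sulfonyl change gives the same step on the core of compound 1, and whether an amine or a methoxy group in place of the chlorine would give a step beyond the scatter.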